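Removing One Chain Double Bond From Compound 1

The source may hold more compounds than are shown below. What is called first, only, known or untested is meant among the compounds shown, and "the series" means these compounds.

In a functional assay on MCF7 cells (Homo sapiens) for antiproliferative activity, read by MTT assay (a lower number here means a stronger inhibitor, a higher number a weaker inhibitor), compound 1 (`CC/C=C\C/C=C\C/C=C\CCCCCCCc1cc(=O)c2c(O)cc(OCOC)c(C)c2o1`) gives 17500 nM. Compound 2 (`CC/C=C\C/C=C\C/C=C\CCCCCCCc1cc(=O)c2c(O)cc(O)c(C)c2o1`), with hydrogen in place of methoxymethyl on an oxygen on an aromatic ring, gives 17500 nM, so the two stand level. Among the compounds with values here, that exchange is the only measured step: no change at the digits printed from compound 1 to compound 2 (within the scatter). Compound 3 (`CCCCC/C=C\C/C=C\CCCCCCCc1cc(=O)c2c(O)cc(OCOC)c(C)c2o1`) keeps the methoxymethyl group of compound 1 and differs in the chain instead: butyl in place of but-1-en-1-yl on a saturated chain carbon bound to a double-bonded chain carbon. Within the data shown here, no measured pair tests a change in the chain, so the measured step bears on this one only indirectly. With nothing pointing either way, no change at the digits printed from compound 1 to compound 3 (within the scatter) is expected to stay within the scatter, with no direction favoured. Compound 3 is estimated at 17500 nM, with an expected range of 8000 nM to 40000 nM.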

Compound 3, half-maximal inhibitory concentration: > 84100 nM
Compound 3: no number, only a limit; the forecaster's own chance of this, stated with the estimate: 10%; at least 4.8-fold (0.68 log units) between middle value and limit.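

The chain proves to be a place where this assay responds: in this assay, the exchange on the aromatic oxygen moved nothing, while butyl in place of but-1-en-1-yl gives an at least 4.8-fold higher number from compound 1 to compound 3 (0.68 log units; beyond the scatter). Compound 3 reads > 84100 nM, which is a limit of the assay and not a number. The step is therefore a minimum only, and it rests on one value at that limit: the limit of > 84100 nM in this assay, at which 1 of the 3 values shown sits.

On these data alone, whether a fully saturated chain, a shorter chain or a chain ending in a carboxylic acid would weaken the number further or bring it back toward compound 1 stays open. Also open, as far as these compounds go, is whether butyl in place of but-1-en-1-yl carries the same step when hydrogen stands in place of methoxymethyl, as in compound 2.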